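The compounds below may be only part of what the source reports. "The series", "measured", "known", "first", "only" and "open" are said of these compounds alone.

Measured so far in a functional assay on the whole organism with Mus musculus as the target, in the rotarod test; a higher number here means that more compound is needed for the effect, a lower number that less compound is needed:
- compound 1 `CN(C(=O)CNC(=O)CN1CCCCC1)c1ccc(Cl)cc1C(=O)c1ccccc1Cl` — a limit only, > 100 mg/kg
- compound 2 `CCCCCC(=O)NCC(=O)N(C)c1ccc(Cl)cc1C(=O)c1ccccc1Cl` — 90 mg/kg
- compound 3 `CC(NC(=O)CN)C(=O)N(C)c1ccc(Cl)cc1C(=O)c1ccccc1Cl` — 8.5 mg/kg

Compound 3 holds the lowest of the two numbers; the step up to it is an 11-fold lower number from compound 2 to compound 3 (1.02 log units; beyond the scatter), which is large and beyond the scatter. The other measured step, an at least 1.1-fold lower number from compound 1 to compound 2 (0.04 log units; that floor lies within the scatter), starts from a limit and is within the scatter at its floor.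

Compound 4 `CN(C(=O)CNC(=O)CN)c1ccc(Cl)cc1C(=O)c1ccccc1Cl` differs from compound 3 by hydrogen in place of methyl on a saturated chain carbon bound to an amide-type nitrogen and a carbonyl carbon. Among the measured compounds shown here, no measured step isolates this change: the step from compound 2 to compound 3 alters the same chain carbon, but together with the terminal amine and the chain length, so the share of the methyl in that step cannot be separated. The step from compound 1 to compound 2 concerns a different part of the chain and is uninformative here.

For the measured compounds named here, with no step that bears on the methyl alone, the expectation for this assay is a step of a 1.2-fold higher number from compound 3 to compound 4 (0.07 log units; within the scatter) from compound 3 to compound 4, that is none beyond the scatter. Compound 4 is therefore estimated at 10 mg/kg, in the range 4 mg/kg to 30 mg/kg.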

Compound 4, dose for half-maximal effect: 27.7 mg/kg
Estimate against measurement, compound 4: 2.8-fold (0.44 log units) below; low and high end bracket the measured number.
By their numbers in this assay, from the lowest: compound 3; then compound 4; then compound 2. At a limit, above all of these: compound 1.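

In this assay, among the compounds shown here, hydrogen in place of methyl on a saturated chain carbon bound to an amide-type nitrogen and a carbonyl carbon gives a 3.3-fold higher number from compound 3 to compound 4 (0.51 log units; beyond the scatter), so the methyl now has a reading of its own, one that the earlier compounds could not separate from the other changes. Amino in place of butyl on a saturated chain carbon bound to a carbonyl carbon gives a 3.2-fold lower number from compound 2 to compound 4 (0.51 log units; beyond the scatter), so the large earlier drop to compound 3 holds two changes, each of which lowers the number beyond the scatter when read on its own. Amino in place of piperidin-1-yl at that same place gives an at least 3.6-fold lower number from compound 1 to compound 4 (0.55 log units; beyond the scatter), and the value of compound 1 from which this step starts is a limit: the limit of > 100 mg/kg in this assay, at which 1 of the 4 values shown sits.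

As far as these compounds go, it remains open whether ethyl or isopropyl in place of methyl on the amide-type nitrogen-bound chain carbon would take the number lower than in compound 3. Also open, from the compounds shown here alone, is whether the step from butyl to amino holds with the methyl present, and how a dimethylamino or hydroxyl group in place of amino would read.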